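From Phenyl to Trimethoxyphenyl: Expected Cytotoxicity of Compound 4

The source may hold more compounds than are shown below. What is called first, only, known or untested is meant among the compounds shown, and "the series" means these compounds.

Compound 1, `O=c1cc(-c2ccc(OCc3ccccc3)cc2)oc2cc(OCCCCCCCCN3CCCC3)ccc12`, gives 54.3% in an ADME assay on HepG2 cells (Homo sapiens) for cytotoxicity, read by MTT assay, with a stated time of 48 h, tested at 10 uM; a higher number here means a stronger effect of the compound at the concentration tested, a lower number a weaker effect.
Compound 2, `O=c1cc(-c2ccccc2)oc2cc(OCCCCCCCCN3CCCC3)ccc12`, gives 8.97% in this assay.
Compound 3, `O=c1cc(-c2ccccc2OCc2ccccc2)oc2cc(OCCCCCCCCN3CCCC3)ccc12`, gives 34.1% in this assay.

Among these three, compound 2 stands lowest in this assay; compound 3 sits nearest to it and compound 1 furthest, both beyond the scatter. Compound 4, `COc1cc(-c2cc(=O)c3ccc(OCCCCCCCCN4CCCC4)cc3o2)cc(OC)c1OC`, is not yet measured. It differs from compound 2 in one place: 3,4,5-trimethoxyphenyl in place of phenyl on an aromatic carbon.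

For the measured compounds named here, two measured steps bear on this change, since both concern a substituent on the same aromatic ring that carries the phenyl of compound 2. Removing the benzyloxy gave a number 45.3 percentage points lower from compound 1 to compound 2 (beyond the scatter), and adding it at another position gave a number 25.1 percentage points higher from compound 2 to compound 3 (beyond the scatter). In both cases the bare phenyl of compound 2 was the weaker partner. Going by the values given here, no measured compound carries a trimethoxyphenyl, so the size of the step is uncertain, but a rise beyond the scatter in this assay is expected, of the order of a number 26 percentage points higher from compound 2 to compound 4 (beyond the scatter). Compound 4 is therefore estimated at 35%, within a range from 12% to 60%.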

Compound 4, a percentage reported as inhibition, at one concentration (the size of the read-out at that concentration, not a potency): 41.4%
Beside the measured number, compound 4's estimate is 6.4 percentage points below it, and the stated range covers the measured number.
By their numbers in this assay, from the lowest: compound 2; then compounds 3 and 4 (each within the scatter of the next); then compound 1.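

In this assay, the replacement of phenyl by 3,4,5-trimethoxyphenyl gives a number 32.4 percentage points higher from compound 2 to compound 4 (beyond the scatter) and shows that a rise at this position does not depend on a benzyloxy group, since compound 4 carries none. Compounds 1, 3 and 4 all stand above compound 2, so among the compounds shown, each of the three substituted rings at this place gives a higher number than the bare phenyl, and none goes against this. Nothing shown gives a measured reason for this rise.

The compounds shown leave open whether a single methoxy group on the phenyl would give a rise of this kind, or whether a hydroxyl group or an amine there would do the same. They also leave open whether the 3,4,5-trimethoxyphenyl would keep its effect with a shorter chain on the shared core.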